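The compounds below may be only part of what the source reports. "The series", "measured", "known", "first", "only" and "open" are said of these compounds alone.

Compound 2, `C[N+](C)(C)[C@H](CCOc1ccc(Br)cc1Br)C(=O)[O-]`, gives > 50 ug/mL in an assay on isolated protein for inhibition of serine/threonine-protein kinase PLK1 (Homo sapiens) (a lower number here means a stronger inhibitor, a higher number a weaker inhibitor), which is a limit of the assay and not a number. Compound 1, `C[N+](C)(C)[C@H](CCOc1c(Br)cc(Br)cc1Br)C(=O)[O-]`, gives > 50 ug/mL in this assay, likewise a limit. Compound 3, `C[N+](C)(C)[C@H](CCOc1c(Cl)cc(Br)cc1Cl)C(=O)[O-]`, gives 6.87 ug/mL in this assay and is the only one of the three with a number. Between compound 1 and compound 2 the change is hydrogen in place of bromo on an aromatic carbon, and the step that the two limits leave unreadable from compound 1 to compound 2 cannot be read because the limit of > 50 ug/mL in this assay, at which 2 of the 3 values shown sit, holds both values.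

Compound 4, `C[N+](C)(C)[C@H](CCOc1c(Br)cc(Br)cc1I)C(=O)[O-]`, differs from compound 2 by iodo in place of hydrogen on an aromatic carbon. For the measured compounds named here, the one measured step in this assay, from compound 1 to compound 2, is the step that bears on this change, and its size is not readable. No direction can therefore be drawn from the measured steps, and the expected step of a number no higher from compound 2 to compound 4 (the limit leaves the size open) reflects that open position. Compound 4 is expected to give 50 ug/mL in this assay, within a range from 15 ug/mL to 150 ug/mL, with a real chance that only a limit is reported again.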

Compound 4, half-maximal inhibitory concentration: 1.45 ug/mL
Compound 4: middle estimate off by 34-fold (1.54 log units), on the high side; the measured number lies below the stated range.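

For the compounds shown here, the iodo group on this aromatic carbon gives the first readable steps in this assay: an at least 34-fold lower number from compound 2 to compound 4 (1.53 log units; beyond the scatter) when it replaces hydrogen, and an at least 34-fold lower number from compound 1 to compound 4 (1.53 log units; beyond the scatter) when it replaces bromo. Filling this position is therefore not enough on its own, as compound 1, with bromo there, stays at the limit of the assay while compound 4, with iodo, gives a number. Both steps are open-ended because the values for compound 1 and compound 2 are limits and not numbers: the limit of > 50 ug/mL in this assay, at which 2 of the 4 values shown sit.

The compounds shown leave open whether a methyl or a trifluoromethyl group on this carbon would give a number as iodo does. They also leave open how far the result holds with a longer chain between the oxygen and the carboxylate-bearing carbon.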